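The compounds below may be only part of what the source reports. "The series", "measured", "known", "first", "only" and "open" are said of these compounds alone.

Compound 1 `Cc1cc(C#N)cc(C)c1Oc1nc(NC2CCCN(Cc3ccc(S(N)(=O)=O)cc3)C2)nc2ccsc12` gives 1170 nM in an ADME assay on MT4 cells (Homo sapiens) for cytotoxicity, read by MTT assay, with a stated time of 5 days; a lower number here means that less compound is tolerated, a higher number that more compound is tolerated.
Compound 2 `Cc1cc(C#N)cc(C)c1Oc1nc(NC2CCCN(Cc3ccc(C(N)=O)cc3)C2)nc2ccsc12` gives 19500 nM in this assay.
Compound 3 `Cc1cc(C#N)cc(C)c1Oc1nc(NC2CCC(NCc3ccc(S(N)(=O)=O)cc3)CC2)nc2ccsc12` gives 3690 nM in this assay.

Among these three numbers, compound 3 stands second highest: compound 1 gives a lower number, beyond the scatter, and compound 2 a higher one, also beyond the scatter.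

Compound 4 `Cc1cc(C#N)cc(C)c1Oc1nc(NC2CCC(NCc3ccc(C(N)=O)cc3)CC2)nc2ccsc12` has not yet been measured in this assay. It differs from compound 3 in one place: carbamoyl in place of sulfamoyl on an aromatic carbon. The same exchange has been measured once already, on a shared core that carries a different ring-amine linker, and it read a 17-fold higher number from compound 1 to compound 2 (1.22 log units; beyond the scatter). For the measured compounds named here, that single step is the only direct guide available, and it was large and upward, toward more compound being tolerated. Going by the values given here, with no second example to check it against, the expectation is that the exchange acts alike on the core of compound 3, so a step of comparable size in the same direction is expected from compound 3 to compound 4, namely a 14-fold higher number from compound 3 to compound 4 (1.13 log units; beyond the scatter). Compound 4 is therefore estimated to give 50000 nM in this assay, with a range from 15000 nM to 150000 nM.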

Compound 4, half-maximal cytotoxic concentration: 7720 nM
The estimate for compound 4 lay 6.5-fold (0.81 log units) above the measured number; the measured number lies below the stated range.
By their numbers in this assay, from the lowest: compound 1; then compound 3; then compound 4; then compound 2.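

On the second core, carbamoyl in place of sulfamoyl on this aromatic carbon again raises the number in this assay, with a 2.1-fold higher number from compound 3 to compound 4 (0.32 log units; beyond the scatter). Until now the exchange had been seen only once, so a single large step could have belonged to that one core; the upward direction has now appeared on both cores, and a newcomer can read it as a trend shared by these two pairs, not as a general rule. The size of the step, however, does not carry over from one core to the other, so the effect of this exchange depends on the rest of the molecule and cannot be read from the two groups alone: the same change on two cores in this assay, a 17-fold higher number (1.22 log units; beyond the scatter) from compound 1 to compound 2 and a 2.1-fold higher number (0.32 log units; beyond the scatter) from compound 3 to compound 4, 8.0-fold (0.90 log units) apart, beyond the scatter of two such steps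

Two pairs cannot show which feature of the cores sets the size of the step, or whether a third core would give a step near either of these two or somewhere else entirely. From the compounds shown here alone, it also stays open how other groups on this same aromatic carbon, such as a carboxylic acid, a primary amine or a methylsulfonyl group, would behave in this assay on either core.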